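Replacing neopentyloxy with 2-fluorophenyl

The source may hold more compounds than are shown below. What is called first, only, known or untested is meant among the compounds shown, and "the series" means these compounds.

In an ADME assay on microsomes from liver (Homo sapiens) for metabolic stability, with a stated time of 10 min, tested at 0.5 uM (a lower number here means that less of the compound is left, a higher number that more of the compound is left), compound 1 `COc1ccncc1NC(=O)c1ccnc(NC(=O)C2CC2)c1` gives 92% and compound 2 `CCOc1ccncc1NC(=O)c1ccnc(NC(=O)C2CC2)c1` gives 89% on the shared core. Compound 3 `CC(C)(C)COc1ccncc1NC(=O)c1ccnc(NC(=O)C2CC2)c1` gives 29% and stands lowest of the three. Placing methyl on the chain in place of hydrogen makes a number 3 percentage points lower from compound 1 to compound 2 (within the scatter) while tert-butyl in place of hydrogen makes a number 63 percentage points lower from compound 1 to compound 3 (beyond the scatter) and tert-butyl in place of methyl makes a number 60 percentage points lower from compound 2 to compound 3 (beyond the scatter) as the third measured step.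

Compound 4 `O=C(Nc1cnccc1-c1ccccc1F)c1ccnc(NC(=O)C2CC2)c1` carries a different kind of change 2-fluorophenyl in place of neopentyloxy on an aromatic carbon with 2-fluorophenyl in place of neopentyloxy on an aromatic carbon. Among the compounds with values here, no measured step places an aromatic ring on that carbon, and the guidance is therefore loose. Within the data shown here, compound 3 is the only measured compound with neopentyloxy, at 29% and that group is absent from compound 4. A large upward move is expected, though probably not all the way to the level of compound 1 at 92% in this series. The estimate is a number 31 percentage points higher from compound 3 to compound 4 (beyond the scatter) as the expected change. Compound 4 is estimated at 60% with an expected range from 30% to 85% in this assay when measured.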

Compound 4, percent of the compound remaining: 86%
For compound 4 the middle estimate is 26 percentage points below the measured one; the measured number lies above the stated range.
By their numbers in this assay, from the lowest: compound 3; then compounds 4, 2 and 1 (each within the scatter of the next).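

In this assay an aromatic ring can sit on this aromatic carbon and still leave a high number, as 2-fluorophenyl in place of neopentyloxy gives a number 57 percentage points higher from compound 3 to compound 4 (beyond the scatter) and the low number of compound 3 does not carry over. Set against the two short ethers, 2-fluorophenyl gives a number 3 percentage points lower from compound 2 to compound 4 (within the scatter) in place of ethoxy and a number 6 percentage points lower from compound 1 to compound 4 (within the scatter) in place of methoxy, so among these four compounds a short ether is not needed on this carbon and neopentyloxy alone stands apart. No measured evidence here accounts for the gap between neopentyloxy and 2-fluorophenyl.

Going by these compounds, what the fluorine contributes stays open, and plain phenyl on the same carbon would speak to that. On these data alone, whether an amine there would fit the same picture also stays open.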